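Outer-ring change from fluoro to acetyl in the amide series

The source may report more compounds than this note shows. Statements on the series, on what has been measured and on what is new or still open speak of the compounds shown alone.

Two compounds of this series carry numbers in a functional assay on MDA-MB-231 cells (Homo sapiens) for antiproliferative activity, read by MTT assay, with a stated time of 72 h; on this read-out lower numbers stand for stronger inhibition and higher numbers for weaker inhibition. Compound 1 `O=C(CCc1cccc2c1B(O)OC2)Nc1ccc(-c2ccccc2)cc1` gives 8800 nM in this assay. Compound 2 `O=C(CCc1cccc2c1B(O)OC2)Nc1cccc(-c2cccc(F)c2)c1` gives 570 nM in this assay, the lowest of the two numbers; its gap to compound 1 is beyond the scatter, so compound 2 is the stronger of the measured pair. For the measured compounds named here, the two measured compounds differ in more than one place, so no measured single-point step exists, and no measured step bears on the change considered next.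

Compound 3 `CC(=O)c1cccc(-c2cccc(NC(=O)CCc3cccc4c3B(O)OC4)c2)c1` is not yet measured. It differs from compound 2 in one place: acetyl in place of fluoro on an aromatic carbon. Nothing measured in the series speaks to an acetyl at that place, so the size of the step is open. The step from compound 2 to compound 3 is expected to be a 1.4-fold higher number from compound 2 to compound 3 (0.15 log units; within the scatter), most likely within the scatter, with either direction possible and a somewhat wider range allowed upward. Compound 3 is estimated at 800 nM in this assay, within a range of 250 nM to 2500 nM.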

Compound 3, half-maximal inhibitory concentration: 52 nM
For compound 3 the middle estimate is 15-fold (1.19 log units) above the measured one; measured number outside the range, below it.
By their numbers in this assay, from the lowest: compound 3; then compound 2; then compound 1.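

The change from 3-fluorophenyl to 3-acetylphenyl in this assay gives an 11-fold lower number from compound 2 to compound 3 (1.04 log units; beyond the scatter) and so marks this aromatic carbon, meta to a large group, as a place where one substitution moves the number well beyond the scatter. The earlier compounds shown here could not show this: compound 1 and compound 2 differ in more than one place and offer no single-point step. Acetyl brings three heavy atoms where fluoro brings one, along with one hydrogen-bond acceptor and a double bond outside aromatic rings, but no measurement on hand ties the step to any of these features.

A single step cannot separate the contribution of the carbonyl from that of the larger group, and an amine, a carboxylic acid or a longer chain ending in a carbonyl on this same carbon would help to tell these readings apart. Also open, going by these compounds, are whether acetyl gives a step of similar size in the frame of compound 1 and whether it holds the number on another carbon of this ring.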